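The compounds below may be only part of what the source reports. "The series", "measured", "known", "first", "only" and "open" are said of these compounds alone.

The study centres on an assay on cells for inhibition of Amine oxidase [flavin-containing] B (Homo sapiens), read by fluorescence, with stated times of 30 min and 15 min, tested at 1 uM; a higher number here means more inhibition at the concentration tested (going by the name of the read-out), a lower number less inhibition. Compound 1 `O=C1Nc2ccc(OCCc3ccc(F)cc3)cc2C1=O` gives 68.7% in this assay, and compound 2 `COc1ccc(OCCOc2ccc3[nH]c(=O)n(C(C)C)c3c2)cc1` gives 15.5%. Compound 3 `CC1(C)C(=O)Nc2ccc(OCc3ccc(F)cc3)cc21` stands apart from both: in this assay compound 3 was recorded as "not active" (no number reported), and no number was reported for it, so where it sits relative to compound 1 and compound 2 cannot be read off a figure. For the measured compounds named here, it is simply the one compound of the three without a measured inhibition value.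

Compound 4 `Cc1ccc(COc2ccc3c(c2)C(C)(C)C(=O)N3)cc1` follows from compound 3 through a single change, (methyl in place of fluoro on an aromatic carbon). Going by the values given here, no measured step exists for this exchange, so any expectation rests on the position of compound 3 alone. With compound 3 recorded as not active, the step from compound 3 to compound 4 is expected to stay within the scatter, in no particular direction, and compound 4 is expected to remain in the low range. The inhibition of compound 4 in this assay is estimated at 10%, with a range from 0% to 30%.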

Compound 4, a percentage reported as inhibition, at one concentration (the size of the read-out at that concentration, not a potency): "not active" (no number reported)
The entry for compound 4 holds no number; no gap can be computed for the estimate.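

In this assay compound 3 and compound 4 both carry a verdict without a number, so no step can be read from the change of 4-fluorophenyl to 4-methylphenyl. Nothing available bears on this result. The compounds shown leave open whether this exchange moves inhibition at all.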